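Compound 3: a fluorophenyl replaces the thiazole on the shared core

This account rests on a few compounds, and the source may have more. Where it says the series, first, only, none or still open, it means among the compounds named here.

Of the compounds shown here, two of the shared core have been measured in a functional assay on CHO-K1 cells for antagonist activity at adenosine receptor A1 (Homo sapiens), read by a beta-galactosidase reporter and cAMP accumulation, with stated times of 15 min and 6 h; a lower number here means a stronger inhibitor, a higher number a weaker inhibitor. Compound 1 `Nc1nc(-c2ccc(C(F)F)o2)nc2sc(Cc3ccccc3)cc12` gives 3000 nM, and compound 2 `Cc1csc(-c2nc(N)c3cc(Cc4ccccc4)sc3n2)n1` gives 1490 nM. Compound 2 carries the lowest of these two numbers, but the step of a 2.0-fold lower number from compound 1 to compound 2 (0.30 log units; within the scatter) lies within the scatter, so the two compounds cannot be told apart on the numbers alone.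

Compound 3 `Nc1nc(-c2cccc(F)c2)nc2sc(Cc3ccccc3)cc12` is not yet measured. It differs from compound 2 in one place: 3-fluorophenyl in place of 4-methyl-1,3-thiazol-2-yl on an aromatic carbon. For the measured compounds named here, the only measured step bearing on this position is a 2.0-fold lower number from compound 1 to compound 2 (0.30 log units; within the scatter), where one aromatic group was exchanged for another aromatic group at the same place and the number moved only within the scatter. Going by the values given here, no measured step describes the entry of a 3-fluorophenyl, so there is no direct precedent for its size.

With one exchange of aromatic groups at this position having given no step beyond the scatter, compound 3 is expected to land near compound 2, and the expected step of a 1.1-fold higher number from compound 2 to compound 3 (0.03 log units; within the scatter) is accordingly small. Compound 3 is estimated at 1600 nM, with a range from 400 nM to 6500 nM.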

Compound 3, inhibition constant: 123 nM
Compound 3: the middle estimate sits 13-fold (1.11 log units) above what was measured; measured number below the stated range.
By their numbers in this assay, from the lowest: compound 3; then compounds 2 and 1 (each within the scatter of the next).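

In this assay, this position turns out to be able to move the number well beyond the scatter: 3-fluorophenyl in place of 4-methyl-1,3-thiazol-2-yl gives a 12-fold lower number from compound 2 to compound 3 (1.08 log units; beyond the scatter), and 3-fluorophenyl in place of 5-(difluoromethyl)furan-2-yl gives a 24-fold lower number from compound 1 to compound 3 (1.39 log units; beyond the scatter). The earlier exchange between two five-membered aromatic rings had stayed within the scatter, so the position is not indifferent to the aromatic group it carries, and of the three groups shown, the six-membered ring of carbon only goes with the lowest number, though a single compound cannot separate the ring size, the loss of ring hetero atoms and the fluorine from one another. Nothing available explains the size of these steps.

As far as these compounds go, what the fluorine itself contributes stays open, and a plain phenyl, a chlorophenyl or a pyridine at this position would be the comparison that could tell. From the compounds shown here alone, all three compounds share the rest of the core, so it also stays open whether the step would hold with another group, such as an amide or a methylamine, in place of the amino group.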